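Adding a chloro to compound 3

A few compounds are considered here, and "the series" means these few. Any claim that something is new, unique, unknown or untested is made for them only; others in the source may bear on it.

Measured so far in an ADME assay on L02 cells (Homo sapiens) for cytotoxicity, read by MTT assay, with a stated time of 24 h; a higher number here means a weaker inhibitor, a lower number a stronger inhibitor
- compound 1 `CN1C/C(=C\c2ccncc2)C(=O)/C(=C/c2ccc(C#N)cc2)C1` gives 14000 nM
- compound 2 `O=C1/C(=C/c2cccnc2)CN(S(=O)(=O)c2ccccc2)C/C1=C\c1ccccc1F` gives 15300 nM
- compound 3 `O=C1/C(=C/c2ccncc2)CN(S(=O)(=O)c2ccccc2)C/C1=C\c1ccccc1F` gives 15900 nM

Compound 3 at 15900 nM lies within the usual scatter of both compound 1 and compound 2, so none of the three sets itself apart. Compound 4 `O=C1/C(=C/c2ccncc2)CN(S(=O)(=O)c2ccc(Cl)cc2)C/C1=C\c1ccccc1F` differs from compound 3 in one place, chloro in place of hydrogen on an aromatic carbon and this turns phenylsulfonyl into (4-chlorophenyl)sulfonyl. Going by the values given here, no measured step tests this change directly. Among the compounds with values here, the only measured step is a 1.0-fold higher number from compound 2 to compound 3 (0.02 log units; within the scatter) and it concerns another place in the molecule. Compound 1 lacks the phenylsulfonyl group, yet compound 1 at 14000 nM stays within the same scatter. No shift beyond the scatter is therefore expected in this assay and the expected step is a 1.1-fold lower number from compound 3 to compound 4 (0.06 log units; within the scatter) in no firm direction. Compound 4 is estimated at 14000 nM with 7500 nM to 24000 nM as its expected range.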

Compound 4, half-maximal inhibitory concentration: 15000 nM
The estimate for compound 4 lay 1.1-fold (0.03 log units) below the measured number, within the range that was stated.
By their numbers in this assay, from the lowest: compounds 1, 4, 2 and 3 (each within the scatter of the next).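

In this assay, going by these compounds alone, turning phenylsulfonyl into (4-chlorophenyl)sulfonyl gives a 1.1-fold lower number from compound 3 to compound 4 (0.03 log units; within the scatter), the first direct reading of a change at this place in the molecule. A chloro on this aromatic carbon therefore leaves the cytotoxicity number within the scatter, just as the change between pyridin-3-yl and pyridin-4-yl did elsewhere in the molecule. Nothing measured here offers an explanation for this result. As far as these compounds go, whether an amine or a carboxylic acid on the same aromatic carbon would shift the number beyond the scatter remains open. Also open, from the compounds shown here alone, is whether chloro would give the same result with the pyridin-3-yl group of compound 2 .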